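A few compounds are considered here, and "the series" means these few. Any claim that something is new, unique, unknown or untested is made for them only; others in the source may bear on it.

Compound 1 `Cn1ccc(-c2cccc3c2CCC3c2ncc[nH]2)n1`: > 10000 nM
Compound 2 `CCS(=O)(=O)Nc1cccc(Cc2c[nH]cn2)c1`: > 10000 nM

In a functional assay on CHO cells for agonist activity at Alpha-1B adrenergic receptor (Homo sapiens), read by FLIPR and calcium flux (on this read-out higher numbers stand for an effect only at larger amounts of compound and lower numbers for an effect already at smaller amounts), compound 1 gives > 10000 nM, which is a limit of the assay rather than a number. Compound 2 likewise reaches only a limit, > 10000 nM. Both values sit at the limit of > 10000 nM in this assay, at which 2 of the 2 values shown sit, so compound 1 stands where every measured compound stands. Compound 3 `c1cncc(-c2cccc3c2CCC3c2ncc[nH]2)c1` differs from compound 1 by pyridin-3-yl in place of 1-methyl-1H-pyrazol-3-yl on an aromatic carbon. Among the measured compounds shown here, no measured step shows the size of such a change in this assay, so no movement beyond the scatter is expected; the step from compound 1 to compound 3 is estimated as a step that the limit leaves unreadable from compound 1 to compound 3. For compound 3 the expected value is 15000 nM, with a range from 3000 nM to 60000 nM.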

Compound 3, half-maximal effective concentration: > 10000 nM
Compound 3: a limit, no number; the forecaster's own chance of this, stated with the estimate: 80%; the middle value is on the limit's open side.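

Compound 1 and compound 3 both give a limit rather than a number, so no step between them can be read: the limit of > 10000 nM in this assay, at which 3 of the 3 values shown sit.

The compounds shown leave open whether any structure gives a readable value in this assay, and how pyridin-3-yl truly compares with 1-methyl-1H-pyrazol-3-yl.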